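The compounds below may be only part of what the source reports. "The series", "measured", "known", "first", "only" and "open" are said of these compounds alone.

Four compounds built on one shared core are compared in an assay on CHO cells for binding affinity to Alpha-2B adrenergic receptor (Homo sapiens), read by radioligand binding; a lower number here means a stronger inhibitor, a higher number a weaker inhibitor. Compound 2 `CSc1cc(F)ccc1NCC1=NCCN1` gives 851 nM. Compound 3 `CSc1c(F)cccc1NCC1=NCCN1` has the same atoms as compound 2 joined differently, and the difference between the two cores is not broken down here; in this assay compound 3 gives 3980 nM. Compound 1 `CS(=O)(=O)c1cc(F)ccc1NCC1=NCCN1` carries the change (methylsulfonyl in place of methylsulfanyl on an aromatic carbon). For compound 1 the assay reports only a limit, < 6310 nM. Hence the size of the step that the limit leaves unreadable from compound 2 to compound 1 cannot be read. Compound 4 `CS(=O)(=O)c1c(F)cccc1NCC1=NCCN1` carries the same kind of change, (methylsulfonyl in place of methylsulfanyl on an aromatic carbon), differing in its place by sitting ortho to a fluoro group instead of meta to a fluoro group. With the earlier step unreadable, the expected step of a 2.5-fold higher number from compound 3 to compound 4 (0.40 log units; beyond the scatter) rests on compound 3, which gives 3980 nM in this assay. It also rests on the limit that compound 1 meets, (the limit of < 6310 nM in this assay, at which 1 of the 3 values shown sits). Compound 4 is estimated at 10000 nM, likely between 2500 nM and 40000 nM.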

Compound 4, inhibition constant: < 6310 nM
Compound 4: a limit, no number; the forecaster's own chance of this, stated with the estimate: 65%; at least 1.5-fold (0.19 log units) between middle value and limit.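

Compound 4, like compound 1, is reported only as a limit, so neither step, from compound 3 to compound 4 or from compound 2 to compound 1, can be read. The compounds shown leave open how far methylsulfonyl in place of methylsulfanyl actually moves the number in either case.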